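The source may report more compounds than this note shows. Statements on the series, on what has been measured and on what is new or still open speak of the compounds shown alone.

The study compares three urea analogues in an ADME assay on the whole organism with Oryza sativa as the target, tested at 1 uM; a higher number here means a weaker effect of the compound at the concentration tested, a lower number a stronger effect. Compound 1 `C[C@@H](NC(=O)Nc1ccccc1F)c1ccccc1` gives 95%. Compound 2 `C[C@H](NC(=O)Nc1cccc(F)c1)c1ccccc1` gives 94%, and compound 3 `C[C@H](NC(=O)Nc1cc(F)ccc1F)c1ccccc1` gives 98%. The difference between the core of compound 1 and the core of compound 2 is not broken down here. Going from compound 2 to compound 3 the change is fluoro in place of hydrogen on an aromatic carbon, and the step that came with it is a number 4 percentage points higher from compound 2 to compound 3 (within the scatter). Compound 4 `C[C@@H](NC(=O)Nc1c(F)cccc1F)c1ccccc1` has not yet been measured. It arises from compound 1 through (fluoro in place of hydrogen on an aromatic carbon). Going by the values given here, this is the same kind of change as the one from compound 2 to compound 3, but not the same: the incoming fluoro in compound 4 stands meta to a fluoro group, whereas in compound 3 it stands para to a fluoro group. Since all three measured values lie within the scatter of one another and the measured fluoro step was small, the step expected from compound 1 to compound 4 in this assay is a number 2 percentage points higher from compound 1 to compound 4 (within the scatter), a size resting on a number 4 percentage points higher from compound 2 to compound 3 (within the scatter). Compound 4 is thus estimated at 97%, between 91% and 101%.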

Compound 4, a percentage reported as activity, at one concentration (the size of the read-out at that concentration, not a potency): 100%
Compound 4: the middle estimate sits 3 percentage points below what was measured; the range from low to high includes it.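

In this assay, fluoro in place of hydrogen on an aromatic carbon of the core of compound 1 gives a number 5 percentage points higher from compound 1 to compound 4 (within the scatter), and beside the earlier case the change shows no difference between the two cores: the same change on two cores in this assay, a number 4 percentage points higher (within the scatter) from compound 2 to compound 3 and a number 5 percentage points higher (within the scatter) from compound 1 to compound 4, 1 percentage points apart, within the scatter of two such steps. Both steps lie within the scatter, so what carries over from one core to the other is the lack of a step that can be told apart from repeat measurement, not a shift of dependable size or direction. The incoming fluoro in compound 4 stands meta to a fluoro group, and two cases cannot show that the same would hold at other places on the ring or on other cores in the series.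

The compounds shown carry only fluoro on the aromatic ring of the urea, which leaves open what a chlorine, a methoxy group or an amine would do there. From the compounds shown here alone, it also remains open whether any such group would give a step in this assay that lies beyond the scatter.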